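From Compound 2 to Compound 3 on Endothelial Cells

The source may report more compounds than this note shows. Statements on the series, on what has been measured and on what is new or still open speak of the compounds shown alone.

Measured so far:
Compound 1, `Cc1cccc(-n2nncc2CN2C(=O)C3(C(C#N)=C(N)Oc4c3c3nc5ccccc5nc3c3ccccc43)c3ccccc32)c1`: in an ADME assay on HUVEC cells (Homo sapiens) for antiproliferative activity, read by MTT assay, with a stated time of 48 h (a lower number here means a stronger inhibitor, a higher number a weaker inhibitor), compound 1 gives > 50000 nM, which is a limit of the assay and not a number.
Compound 2, `N#CC1=C(N)Oc2c(N)cc3nc4ccccc4nc3c2C12C(=O)N(Cc1cnnn1-c1cccc(Br)c1)c1ccccc12`: in this assay compound 2 gives > 50000 nM, again a limit of the assay rather than a number.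

For the measured compounds named here, compound 2 therefore stands at the limit, and so does the only other value shown, as the limit of > 50000 nM in this assay, at which 2 of the 2 values shown sit, records. Going by the values given here, no numerical step between measured compounds exists, so nothing shows how far any change moves the read-out. Compound 3, `Cc1cc(C)cc(-n2nncc2CN2C(=O)C3(C(C#N)=C(N)Oc4c(N)cc5nc6ccccc6nc5c43)c3ccccc32)c1`, differs from compound 2 by 3,5-dimethylphenyl in place of 3-bromophenyl on an aromatic nitrogen. With both shown values at the limit, the step in this assay is expected to be none beyond the scatter, and compound 3 is expected to remain at the limit as well. Compound 3 is estimated at 60000 nM, within 25000 nM to 150000 nM, meaning an expected step that the limit leaves unreadable from compound 2 to compound 3.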

Compound 3, half-maximal inhibitory concentration: > 50000 nM
Compound 3 ended at the assay's limit; the forecaster's own chance of this, stated with the estimate: 80%; the middle value lies beyond the limit too.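

Compound 2 and compound 3 both sit at a limit of the assay and not at a number, so no step between them can be read: the limit of > 50000 nM in this assay, at which 3 of the 3 values shown sit.

The compounds shown leave open how strongly any of them acts in this assay, and how far 3,5-dimethylphenyl in place of 3-bromophenyl moves the read-out.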